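Three hydrazones measured, a dibromo-hydroxyphenyl analogue still to come

The source may hold more compounds than are shown below. What is called first, only, known or untested is meant among the compounds shown, and "the series" means these compounds.

Measured so far in a functional assay on HCT-116 cells (Homo sapiens) for inhibition, read by MTT assay, with a stated time of 48 h; a lower number here means a stronger inhibitor, a higher number a weaker inhibitor:
- compound 1 `O=C(CSc1nnc(-c2ccncc2)n1-c1ccccc1)N/N=C/c1ccccc1` gives 14700 nM
- compound 2 `COc1ccc(/C=N/NC(=O)CSc2nnc(-c3ccncc3)n2-c2ccccc2)cc1` gives 19200 nM
- compound 3 `O=C(CSc1nnc(-c2ccncc2)n1-c1ccccc1)N/N=C/c1ccccc1F` gives 18000 nM

All three share the same core and differ only in the aromatic ring hanging from the carbon that is double-bonded to nitrogen. Compound 3 sits second highest of the three numbers: the step from compound 1 to compound 3 is a 1.2-fold higher number from compound 1 to compound 3 (0.09 log units; within the scatter), and the step from compound 2 to compound 3 is a 1.1-fold lower number from compound 2 to compound 3 (0.03 log units; within the scatter). The change from compound 1 to compound 2, a 1.3-fold higher number from compound 1 to compound 2 (0.12 log units; within the scatter), is likewise small. In short, none of the ring changes seen so far moved this assay beyond its scatter.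

Compound 4 `O=C(CSc1nnc(-c2ccncc2)n1-c1ccccc1)N/N=C/c1cc(Br)cc(Br)c1O` goes further: 3,5-dibromo-2-hydroxyphenyl in place of 2-fluorophenyl on a carbon with a double bond to nitrogen. This is a larger change than any measured step, so the three small steps give only weak guidance. They bear on it by showing that this position tolerated substitution without loss, and nothing shows a gain either. A modest move toward a lower number is expected for compound 4, giving an estimated 9000 nM, between 2500 nM and 30000 nM, which would be an expected step of a 2.0-fold lower number from compound 3 to compound 4 (0.30 log units; within the scatter) that may well lie within the scatter.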

Compound 4, half-maximal inhibitory concentration: 4500 nM
For compound 4 the middle estimate is 2.0-fold (0.30 log units) above the measured one; the range from low to high includes it.
By their numbers in this assay, from the lowest: compound 4; then compounds 1, 3 and 2 (each within the scatter of the next).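

In this assay, among these compounds, the aromatic ring on the carbon with a double bond to nitrogen can change the number beyond the scatter, which none of the earlier steps showed: 3,5-dibromo-2-hydroxyphenyl gives a 4.0-fold lower number from compound 3 to compound 4 (0.60 log units; beyond the scatter), a 4.3-fold lower number from compound 2 to compound 4 (0.63 log units; beyond the scatter) and a 3.3-fold lower number from compound 1 to compound 4 (0.51 log units; beyond the scatter). All three steps are modest, yet they set compound 4 apart as the strongest inhibitor of the four, so this position allows a gain as well as tolerating substitution. Nothing available here explains that gain.

The change brings in bromine and hydroxy together, so the compounds shown cannot separate what each contributes. They also leave open how this position would respond to a ring carrying an amine or a carboxylic acid.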